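Taking the phenyl group off compound 2

A few compounds are considered here, and "the series" means these few. Any claim that something is new, unique, unknown or untested is made for them only; others in the source may bear on it.

In a functional assay on the whole organism with Mus musculus as the target (on this read-out lower numbers stand for an effect already at smaller amounts and higher numbers for an effect only at larger amounts of compound), compound 1 `c1ccc(-c2cccc(OCCn3ccnc3)c2)cc1` gives > 200 mg/kg as a limit of the assay and not as a number. Compound 2 `c1ccc(-c2ccc(OCCn3ccnc3)cc2)cc1` also stands only at a limit, > 400 mg/kg and no number, so its true position is open. Compound 3 `c1ccc(OCCn2ccnc2)cc1` carries hydrogen in place of phenyl on an aromatic carbon. Within the data shown here, no measured step guides this change, so its size can only be estimated. A shift toward smaller doses beyond the scatter in this assay is expected (an at least 2.6-fold lower number from compound 2 to compound 3 (0.42 log units; beyond the scatter)). For compound 3 the estimated dose is 150 mg/kg with an expected range from 50 mg/kg to 400 mg/kg and a real chance of another limit.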

Compound 3, dose for half-maximal effect: > 280 mg/kg
Compound 3: no number, only a limit; the forecaster's own chance of this, stated with the estimate: 40%; at least 1.8-fold (0.27 log units) between middle value and limit.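

In this assay, compound 1, compound 2 and compound 3 all stand only at limits of the assay, and the steps from compound 1 and compound 2 to compound 3 cannot be read. The compounds shown leave open whether hydrogen in place of phenyl changes the dose at all.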